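Does branching the amine chain weaken compound 3?

This account rests on a few compounds, and the source may have more. Where it says the series, first, only, none or still open, it means among the compounds named here.

Of the compounds shown here, three sharing one core have been tested in a functional assay on HT cells (Homo sapiens) for antiproliferative activity, read by fluorescence, with a stated time of 72 h; a higher number here means a weaker inhibitor of growth, a lower number a stronger inhibitor of growth. Compound 1 `CC(C)c1n[nH]c2c(NCc3ccc(-c4ccccn4)cc3)nc(SCCO)nc12` gives 48 nM, compound 2 `CC(C)c1n[nH]c2c(NCc3ccc(-c4ccccn4)cc3)nc(SCC(C)(C)O)nc12` gives 507 nM, and compound 3 `CC(C)c1n[nH]c2c(NCc3ccc(-c4ccccn4)cc3)nc(SCCN)nc12` gives 22 nM, the lowest number of the three and so the strongest inhibitor of growth here.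

Compound 4 `CC(C)c1n[nH]c2c(NCc3ccc(-c4ccccn4)cc3)nc(SCC(C)(C)N)nc12` differs from compound 3 in one group: 1-amino-1-methylethyl in place of aminomethyl on a saturated chain carbon bound to a sulfur. Among the compounds with values here, the closest precedent is the same branching on the hydroxy chain, which gave an 11-fold higher number from compound 1 to compound 2 (1.02 log units; beyond the scatter). Exchanging hydroxy for amino on the unbranched chain gave a much smaller change, a 2.2-fold lower number from compound 1 to compound 3 (0.34 log units; beyond the scatter). The branching precedent rests on this single pair, and no branched amine has yet been measured, so it may not carry over in full.

In this assay, a large move towards weaker growth inhibition is expected, an estimated 9.1-fold higher number from compound 3 to compound 4 (0.96 log units; beyond the scatter). The estimate for compound 4 is 200 nM, with an expected range from 60 nM to 600 nM.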

Compound 4, concentration for 50% growth inhibition: 85 nM
Beside the measured number, compound 4's estimate is 2.4-fold (0.37 log units) above it, and the stated range covers the measured number.
By their numbers in this assay, from the lowest: compound 3; then compounds 1 and 4 (each within the scatter of the next); then compound 2.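

Branching also weakens growth inhibition on the amine chain, with a 3.9-fold higher number from compound 3 to compound 4 (0.59 log units; beyond the scatter), but this is a smaller penalty than an 11-fold higher number from compound 1 to compound 2 (1.02 log units; beyond the scatter) on the hydroxy chain. Seen the other way, amino in place of hydroxy gives a 6.0-fold lower number from compound 2 to compound 4 (0.78 log units; beyond the scatter), so the size of this exchange depends on whether the chain is branched: the same change on two cores in this assay, a 2.2-fold lower number (0.34 log units; beyond the scatter) from compound 1 to compound 3 and a 6.0-fold lower number (0.78 log units; beyond the scatter) from compound 2 to compound 4, 2.7-fold (0.44 log units) apart, beyond the scatter of two such steps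

Made together, the two changes nearly offset each other, with a 1.8-fold higher number from compound 1 to compound 4 (0.25 log units; within the scatter).

Each of these readings rests on a single pair of compounds, and the data give no reason for the difference between the two chains. On these data alone, how a longer chain such as 3-aminopropyl, or a methylamino group in place of amino, would behave at this position stays open.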